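Swapping a Saturated Ring for a Pyrazole Before Measurement

This account rests on a few compounds, and the source may have more. Where it says the series, first, only, none or still open, it means among the compounds named here.

Three compounds share one core and were tested in an ADME assay on cells (Hepatocyte, Rattus norvegicus) for metabolic stability, read by HPLC, with a stated time of 30 min, tested at 1 uM; on this read-out lower numbers stand for slow clearance and higher numbers for fast clearance. Compound 1 `COCc1ccc(-c2ccc3nnc(C(N)=O)c(N[C@@H](C)c4nn(C)cc4C)c3c2)cn1` gives 18 uL/min. Compound 2 `Cc1cn(C)nc1[C@H](C)Nc1c(C(N)=O)nnc2ccc(-c3ccc(OCCCN(C)C)nc3)cc12` gives 12 uL/min. Compound 3 `C[C@H](Nc1c(C(N)=O)nnc2ccc(-c3ccc(OCCCN4CCCC4)nc3)cc12)C1CCOCC1` gives 1.9 uL/min, the lowest of the three numbers, with compound 2 the nearest and compound 1 the furthest away, both beyond the scatter.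

Among the measured compounds shown here, the only step between two compounds that differ in one place is a 1.5-fold lower number from compound 1 to compound 2 (0.18 log units; within the scatter), a change at the far end of the molecule that lies within the scatter and does not touch the part altered here.

Compound 4 `Cc1cn(C)nc1[C@H](C)Nc1c(C(N)=O)nnc2ccc(-c3ccc(OCCCN4CCCC4)nc3)cc12` is not yet measured. It differs from compound 3 by 1,4-dimethyl-1H-pyrazol-3-yl in place of oxan-4-yl on a saturated chain carbon bound to a nitrogen on an aromatic ring and a saturated chain carbon. For the measured compounds named here, no measured step isolates this exchange: compound 2 carries the same 1,4-dimethyl-1H-pyrazol-3-yl group as compound 4, but it also differs from compound 3 in a second place, so its values can only be set side by side with those of compound 3, where compound 2 sits well above.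

On that basis an upward step is expected from compound 3 to compound 4, a 4.2-fold higher number from compound 3 to compound 4 (0.62 log units; beyond the scatter). Compound 4 is expected to come out near 8 uL/min, in a range from 3 uL/min to 20 uL/min.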

Compound 4, intrinsic clearance in a liver preparation (reported as CLH), per the amount of preparation that the assay uses in the Hepatocyte assay: 8.1 uL/min
Estimate against measurement, compound 4: 1.0-fold (0.01 log units) below; the range from low to high includes it.
By their numbers in the Hepatocyte assay, from the lowest: compound 3; then compounds 4, 2 and 1 (each within the scatter of the next, the first and the last beyond it).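

In the Hepatocyte assay the exchange of oxan-4-yl for 1,4-dimethyl-1H-pyrazol-3-yl can now be read alone, as a 4.3-fold higher number from compound 3 to compound 4 (0.63 log units; beyond the scatter), so the group on this saturated chain carbon matters for clearance when the rest of the molecule stays the same. With that pyrazole held in place, the far end of the molecule gives a 1.5-fold lower number from compound 2 to compound 4 (0.17 log units; within the scatter) for pyrrolidin-1-yl in place of dimethylamino, and a 2.2-fold lower number from compound 1 to compound 4 (0.35 log units; beyond the scatter) for 3-(pyrrolidin-1-yl)propoxy in place of methoxymethyl, so only the larger exchange at that end leaves the scatter. In a physicochemical assay for lipophilicity, using the shake flask method, measured as octanol-water partition, with a stated time of 30 min, at pH 7.4 (on this read-out lower numbers stand for lower lipophilicity and higher numbers for higher lipophilicity), compound 3 gives 1.9 and compound 4 gives 2.1, which is a number 0.20 log units higher from compound 3 to compound 4 (within the scatter), so the clearance step at this position comes without a distribution coefficient step beyond the scatter.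

Why clearance responds to this exchange remains open, as no measurement here bears on the cause. Also open, as far as these compounds go, is where other groups on this carbon, such as a cyclohexyl or phenyl ring, would fall, and whether the oxan-4-yl exchange gives a similar step when methoxymethyl occupies the far end.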